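This account rests on a few compounds, and the source may have more. Where it says the series, first, only, none or still open, it means among the compounds named here.

In an ADME assay on HeLa cells (Homo sapiens) for cytotoxicity, read by ATP content, with a stated time of 3 days (on this read-out higher numbers stand for lower toxicity in this test and lower numbers for higher toxicity in this test), compound 1 `CS(=O)(=O)CCCn1c(Cn2c(=O)n(C3CN(S(C)(=O)=O)C3)c3ccncc32)cc2cc(Cl)ccc21` gives > 50000 nM, which is a limit of the assay rather than a number. Compound 2 `N=C(CCCn1c(Cn2c(=O)n(C3CC3)c3ccncc32)cc2cc(Cl)ccc21)NO` gives > 50000 nM, again a limit. Compound 3 `O=c1n(Cc2cc3cnccc3n2CCCCO)c2cnccc2n1C1CC1` gives > 100000 nM, also a limit. For the measured compounds named here, compound 2 thus stands where all the values shown stand: two of the three sit at the limit of > 50000 nM in this assay, at which 2 of the 3 values shown sit, and one at the limit of > 100000 nM in this assay, at which 1 of the 3 values shown sits, so no step between measured compounds can be counted. Compound 4 `O=C(O)CCCn1c(Cn2c(=O)n(C3CC3)c3ccncc32)cc2cc(Cl)ccc21` differs from compound 2 by a group of 3 heavy atoms (1 carbon, 2 oxygen; no ring) in place of a group of 4 heavy atoms (1 carbon, 2 nitrogen, 1 oxygen; no ring), on a saturated chain carbon, three bonds along the chain from an aromatic nitrogen. With every measured compound at a limit, no step beyond the scatter is expected from compound 2 to compound 4. The estimate for compound 4 is 60000 nM, with a range from 20000 nM to 200000 nM. That estimate means an expected step that the limit leaves unreadable from compound 2 to compound 4.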

Compound 4, half-maximal cytotoxic concentration: > 50000 nM
Compound 4 was reported as a limit (the forecaster's own chance of this, stated with the estimate: 85%); the middle value is on the limit's open side.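

In this assay compound 4 gives > 50000 nM, a limit. Compound 2 gives > 50000 nM, also a limit. No step can be read between compound 2 and compound 4. The compounds shown leave open where the true cytotoxic concentration of either lies.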